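A few compounds are considered here, and "the series" means these few. Any claim that something is new, unique, unknown or untested is made for them only; others in the source may bear on it.

Measured compounds:

Compound 1, `CCCCCCSc1nnc(COc2ccc(-n3cnnc3)cc2)o1`, gives 28.4 mg/kg in a functional assay on the whole organism (strain Kunming) with Mus musculus as the target, with a stated time of 30 min; a lower number here means that less compound is needed, a higher number that more compound is needed for the effect.
Compound 2, `CCCCCSc1nnc(COc2ccc(NC(C)=O)cc2)o1`, gives 28.1 mg/kg.
Compound 3, `CCCCCCSc1nnc(COc2ccc3c(c2)CCC(=O)N3)o1`, gives 17.9 mg/kg.

These three compounds share the same core and differ in the group attached to it and in the length of the saturated chain on the sulfur. Compound 2 stands in the middle of the three numbers, but neither neighbour is separated from it by more than the usual scatter: compound 1 gives a value that matches it almost exactly, and the gap to compound 3 also falls within the scatter. In effect, the three numbers cannot be told apart.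

Compound 4, `CCCCCCSc1nnc(COc2ccc(NC(C)=O)cc2)o1`, has not yet been measured. It differs from compound 2 in one place: methyl in place of hydrogen on a saturated chain carbon, five bonds along the chain from a sulfur. Compounds 1 and 3 already carry this longer chain and give numbers indistinguishable from that of compound 2, so no step beyond the scatter is expected here, in either direction. The expected step of a 1.1-fold lower number from compound 2 to compound 4 (0.03 log units; within the scatter) is therefore essentially flat. Compound 4 is estimated to give 26 mg/kg, with a range from 14 mg/kg to 48 mg/kg.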

Compound 4, dose for half-maximal effect: 26.8 mg/kg
Compound 4: middle estimate off by 1.0-fold (0.01 log units), on the low side, within the range that was stated.
By their numbers in this assay, from the lowest: compounds 3, 4, 2 and 1 (each within the scatter of the next).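

Going by these compounds alone, this is the first direct test of this position with everything else held fixed. In this assay, methyl in place of hydrogen on a saturated chain carbon, five bonds along the chain from a sulfur, gives a 1.0-fold lower number from compound 2 to compound 4 (0.02 log units; within the scatter), so this one-carbon extension has no effect that can be told from the scatter. With the chain held the same, acetamido in place of 4H-1,2,4-triazol-4-yl on an aromatic carbon gives a 1.1-fold lower number from compound 1 to compound 4 (0.03 log units; within the scatter), and no measurement shown here explains either flat step.

Going by these compounds, it remains open whether a much shorter chain such as ethyl, or a much longer one such as decyl, would move the number beyond the scatter. The same question stands for a chain ending in an amine or a carboxylic acid.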